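A few compounds are considered here, and "the series" means these few. Any claim that something is new, unique, unknown or untested is made for them only; others in the source may bear on it.

Working notes on a small series of inhibitors tested in an assay on microsomes from liver for inhibition of 3-hydroxy-3-methylglutaryl-coenzyme A reductase (Rattus norvegicus); a lower number here means a stronger inhibitor, a higher number a weaker inhibitor. Of the compounds shown here, two have been measured so far. Compound 1, `CC(C)c1nc(-c2ccc(F)cc2)c(-c2ccc(F)cc2)n1CC[C@@H](O)C[C@@H](O)CC(=O)O`, gives 316 nM in this assay. Compound 2, `O=C(O)C[C@H](O)C[C@H](O)CCn1c(C(F)(F)F)nc(-c2ccc(F)cc2)c1-c1cccc(Cl)c1`, gives 41 nM in this assay, the lower of the two numbers, and its gap to compound 1 lies beyond the scatter, so compound 2 is the stronger inhibitor of the pair. The two differ in more than one place, so the gap between them cannot be read as the effect of any single change.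

The next compound, compound 3, `COc1cccc(-c2c(-c3ccc(F)cc3)nc(C(F)(F)F)n2CC[C@@H](O)C[C@@H](O)CC(=O)O)c1`, is a single-point variant of compound 2: methoxy in place of chloro on an aromatic carbon. For the measured compounds named here, no measured pair carries this particular change, so the size of the step rests on expectation alone. A modest loss is expected, amounting to a 2.0-fold higher number from compound 2 to compound 3 (0.29 log units; within the scatter), a step of about the width of the scatter or a little beyond it, toward a weaker inhibitor. On that basis compound 3 is estimated at 80 nM in this assay, with a range from 30 nM to 250 nM.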

Compound 3, half-maximal inhibitory concentration: 135 nM
The estimate for compound 3 lay 1.7-fold (0.23 log units) below the measured number; measured number inside the range.
By their numbers in this assay, from the lowest: compound 2; then compound 3; then compound 1.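

In this assay, for the compounds shown here, the exchange of chloro for methoxy gives the first reading of a change in one place: a 3.3-fold higher number from compound 2 to compound 3 (0.52 log units; beyond the scatter), a step beyond the scatter and toward a weaker inhibitor. The position, on an aromatic carbon of a six-membered aromatic ring of carbon only and meta to a large group, is therefore sensitive to what it carries, and with the rest of compound 2 held fixed, chloro and methoxy are not interchangeable there. The data hold nothing that tells which difference between the two groups lies behind the step, so this single pair records its size and direction only.

From the compounds shown here alone, with just this pair at the position, there is no trend to read, and it remains open whether hydrogen, fluoro, methyl, hydroxy or an amine at this place would give a number nearer that of compound 2 or that of compound 3. Going by these compounds, it is also open whether the same exchange would give a step of similar size with a group other than trifluoromethyl on the shared core.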